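A few compounds are considered here, and "the series" means these few. Any claim that something is new, unique, unknown or untested is made for them only; others in the source may bear on it.

Measured so far:
- compound 1 `Cc1ccccc1Nc1nc(Nc2cc(Cl)ccn2)ncc1Cl`: 41500 nM
- compound 2 `COc1ccccc1CNc1nc(Nc2ccc(N3CCN(C)CC3)cn2)ncc1Cl`: 25500 nM

In an ADME assay on L02 cells (Homo sapiens) for inhibition, read by CCK-8 assay, with a stated time of 48 h (on this read-out higher numbers stand for weaker inhibition of growth and lower numbers for stronger inhibition of growth), compound 2 gives 25500 nM, within the scatter of compound 1 at 41500 nM. Compound 3 `CN1CCN(c2ccc(Nc3ncc(Cl)c(Nc4ccc(C(C)(C)C)cc4)n3)nc2)CC1` is still unmeasured. It follows from compound 2 by one change on a nitrogen on an aromatic ring: 4-(tert-butyl)phenyl in place of 2-methoxybenzyl on a nitrogen on an aromatic ring. For the measured compounds named here, no step between measured compounds shows what such a change does in this assay, so no change beyond the scatter is expected. The estimated 1.3-fold lower number from compound 2 to compound 3 (0.11 log units; within the scatter) therefore stays small. Compound 3 is expected at 20000 nM, with an estimated range of 7000 nM to 50000 nM.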

Compound 3, concentration for 50% growth inhibition: 6070 nM
For compound 3 the middle estimate is 3.3-fold (0.52 log units) above the measured one, and the stated range ends above it.
By their numbers in this assay, from the lowest: compound 3; then compounds 2 and 1 (each within the scatter of the next).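

In this assay the group on this nitrogen on an aromatic ring clearly affects the read-out: 4-(tert-butyl)phenyl in place of 2-methoxybenzyl gives stronger inhibition of growth (a 4.2-fold lower number from compound 2 to compound 3 (0.62 log units; beyond the scatter)). Compounds 1 and 2 differ in more than one place, so they could not isolate this position. No measurement shown explains the step. Still open, going by these compounds, is whether the shift follows the tert-butyl group, the absence of the methoxy group or the absence of the benzyl methylene. Plain phenyl, 4-methoxyphenyl and 4-(tert-butyl)benzyl on this nitrogen would separate these readings.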